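A few compounds are considered here, and "the series" means these few. Any claim that something is new, unique, unknown or untested is made for them only; others in the source may bear on it.

Measured in a functional assay on MDA-MB-231 cells (Homo sapiens) for inhibition, read by MTT assay, with a stated time of 72 h; on this read-out lower numbers stand for stronger inhibition and higher numbers for weaker inhibition:
- compound 1 `CO[C@H](c1ccccc1)[C@H]1O[C@@H]2CC(=O)O[C@@H]2[C@H]1O`: 64 nM
- compound 2 `CO[C@@H]1[C@H]2OC(=O)C[C@H]2O[C@@H]1[C@@H](OC)c1ccccc1`: 2650 nM

Compound 2 has the higher of the two numbers, which makes it the weaker inhibitor in this assay, and its gap to compound 1 lies beyond the usual scatter of repeat measurements. Compound 3 `CO[C@@H]1[C@H]2OC(=O)C[C@H]2O[C@@H]1[C@H](OC)c1ccccc1` is a close relative of compound 2: the two compounds have the same atoms and bonds and differ only in configuration as drawn: 1 of 5 stereo elements differ; a stereocentre at a saturated chain carbon is drawn S in compound 2 and R in compound 3. Within the data shown here, no measured pair here shows what such a change does, so any forecast is uncertain. Among the measured compounds shown here, since compound 2 sits at 2650 nM, the high end of the numbers so far, a move towards a lower number seems the more likely direction. The expected move is moderate, and a 2.2-fold lower number from compound 2 to compound 3 (0.34 log units; beyond the scatter) is only an estimate. For compound 3 the estimated value is 1200 nM, with an expected range from 200 nM to 6000 nM.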

Compound 3, half-maximal inhibitory concentration: 1360 nM
Compound 3: middle estimate off by 1.1-fold (0.05 log units), on the low side; the range from low to high includes it.
By their numbers in this assay, from the lowest: compound 1; then compounds 3 and 2 (each within the scatter of the next).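

In this assay the new result gives a 1.9-fold lower number from compound 2 to compound 3 (0.29 log units; within the scatter) and so no readable effect of the stereocentre at a saturated chain carbon, and this comparison is a clean one: the fact that compounds 2 and 3 differ only in the configuration as drawn. The larger change lies elsewhere: methyl in place of hydrogen on an oxygen on a saturated carbon gives a 21-fold higher number from compound 1 to compound 3 (1.33 log units; beyond the scatter) and this single swap could not be read from the earlier pair, which differed in two places. Among these three compounds, then, only the swap at that oxygen goes with a clear loss of inhibition.

As far as these compounds go, what an ethyl group or an acetyl group on that oxygen would do stays open. Also open, from the compounds shown here alone, is whether the stereocentre matters in a compound that keeps hydrogen on that oxygen.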